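From allyl(methyl)amino to (4-fluorobenzyl)oxy on the carbonyl

A few compounds are considered here, and "the series" means these few. Any claim that something is new, unique, unknown or untested is made for them only; others in the source may bear on it.

Measured in a functional assay on HepG2 cells (Homo sapiens), read by MTT assay, with a stated time of 48 h; a higher number here means a weaker inhibitor, a lower number a stronger inhibitor:
compound 1 `CCn1c(C(=O)NCCN)ccc1C(CC)(CC)c1ccc(OCC(O)C(C)(C)C)c(C)c1`: 176 nM
compound 2 `C=CCN(C)C(=O)c1ccc(C(CC)(CC)c2ccc(OCC(O)C(C)(C)C)c(C)c2)n1CC`: > 50000 nM

Compound 2 gives > 50000 nM in this assay, which is a limit of the assay and not a number. It stands at the far end of the two values shown (the limit of > 50000 nM in this assay, at which 1 of the 2 values shown sits). Compound 3 `CCn1c(C(=O)OCc2ccc(F)cc2)ccc1C(CC)(CC)c1ccc(OCC(O)C(C)(C)C)c(C)c1` differs from compound 2 as follows: (4-fluorobenzyl)oxy in place of allyl(methyl)amino on a carbonyl carbon. In words, (4-fluorobenzyl)oxy takes the place of allyl(methyl)amino on a carbonyl carbon.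

Among the compounds with values here, the one measured step that bears on this is an at least 280-fold higher number from compound 1 to compound 2 (2.45 log units; beyond the scatter), a large loss on that same carbonyl carbon. Compound 3, like compound 2, lacks the (2-aminoethyl)amino group of compound 1, which gives 176 nM in this assay. Within the data shown here, no measured step covers (4-fluorobenzyl)oxy itself, so a return towards compound 1 is not expected. The expected step is an at least 1.2-fold lower number from compound 2 to compound 3 (0.09 log units; that floor lies within the scatter), and a result reported only as a limit is quite possible. For compound 3 the estimated value is 40000 nM, with an expected range of 6000 nM to 80000 nM.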

Compound 3, half-maximal inhibitory concentration: > 50000 nM
Compound 3 gave a limit, no number; the forecaster's own chance of this, stated with the estimate: 55%; middle value at least 1.2-fold (0.09 log units) away from the limit.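

On this carbonyl carbon, (4-fluorobenzyl)oxy in place of (2-aminoethyl)amino brings an at least 280-fold higher number from compound 1 to compound 3 (2.45 log units; beyond the scatter) in this assay, so a second replacement of quite a different kind, one with an aromatic ring and no nitrogen, also ends in a large loss. Of the three compounds, only compound 1 gives a value short of the limit. The step from compound 2 to compound 3 cannot be read, and compound 3 joins compound 2 at what is a limit of the assay and not a number: the limit of > 50000 nM in this assay, at which 2 of the 3 values shown sit.

On these data alone, it remains open how far the activity of compound 2 and compound 3 lies beyond that limit. As far as these compounds go, it is also open whether a longer chain ending in an amine, or a carboxylic acid, on this carbonyl carbon would give a measurable value.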